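The source may hold more compounds than are shown below. What is called first, only, known or untested is meant among the compounds shown, and "the series" means these compounds.

Three compounds share one core and differ only in the ring at the end of the side chain. In a functional assay on cells for antagonist activity at Orexin/Hypocretin receptor type 1 (Homo sapiens), read by fluorescence and calcium flux, with a stated time of 30 min (a higher number here means a weaker inhibitor, a lower number a stronger inhibitor), compound 1 `CCN(C(=O)c1cc(C)ccc1-n1nccn1)[C@@H](C)Cn1cc(-c2ccc(F)cn2)nn1` gives 1.93 nM. In the same test compound 2 `CCN(C(=O)c1cc(C)ccc1-n1nccn1)[C@@H](C)Cn1nnc(-c2ccc(F)cn2)n1` gives 1.1 nM, and compound 3 `CCN(C(=O)c1cc(C)ccc1-n1nccn1)[C@@H](C)Cn1nnc(-c2ccc(F)cc2)n1` gives 0.82 nM, the lowest of the three numbers, with compound 2 nearest and compound 1 furthest. Within the data shown here, the single measured step, a 1.3-fold lower number from compound 2 to compound 3 (0.13 log units; within the scatter), concerns that end ring alone. Compound 4 `CCN(C(=O)c1cc(C)ccc1-c1ncccn1)[C@@H](C)Cn1nnc(-c2ccc(F)cc2)n1` differs from compound 3 by pyrimidin-2-yl in place of 2H-1,2,3-triazol-2-yl on an aromatic carbon. Among the measured compounds shown here, no measured step touches this position, so the data give no direction for the change. For compound 4 an expected step of a 1.2-fold higher number from compound 3 to compound 4 (0.09 log units; within the scatter) is the plainest reading. In this assay compound 4 is therefore estimated at 1 nM, between 0.4 nM and 3 nM.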

Compound 4, half-maximal inhibitory concentration: 1.81 nM
Compound 4: the middle estimate sits 1.8-fold (0.26 log units) below what was measured; the range from low to high includes it.
By their numbers in this assay, from the lowest: compounds 3, 2, 4 and 1 (each within the scatter of the next, the first and the last beyond it).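

In this assay, among these compounds, a 2.2-fold higher number from compound 3 to compound 4 (0.34 log units; beyond the scatter) gives the first reading at this position, ortho to a large group and para to a methyl group. Unlike the change in the end ring, this step lies beyond the scatter, so the ring at this position does register, though pyrimidin-2-yl is accepted there at only a modest cost. Nothing available accounts for the step.

From the compounds shown here alone, whether a non-ring group such as an amine or a methoxy group would be accepted at this position remains open. So does whether pyrimidin-2-yl would give a similar step alongside the 5-fluoropyridin-2-yl end ring of compound 2.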